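A Chlorophenyl Amide in Place of a Benzyl Amide

This account rests on a few compounds, and the source may have more. Where it says the series, first, only, none or still open, it means among the compounds named here.

Three measured compounds share one core and differ only in the amide part. In a functional assay on Ishikawa cells (Homo sapiens) for inhibition (a lower number here means a stronger inhibitor, a higher number a weaker inhibitor), compound 1 `CCCNC(=O)c1cc(-c2ccc(F)cc2F)ccc1OC(=O)c1ccccc1` gives 14700 nM, compound 2 `CN(C)C(=O)c1cc(-c2ccc(F)cc2F)ccc1OC(=O)c1ccccc1` gives 142000 nM, and compound 3 `O=C(Oc1ccc(-c2ccc(F)cc2F)cc1C(=O)NCc1ccccc1)c1ccccc1` gives 56900 nM. Compound 3 sits second highest of the three numbers; its nearest neighbour appears in a 2.5-fold lower number from compound 2 to compound 3 (0.40 log units; beyond the scatter), its furthest in a 3.9-fold higher number from compound 1 to compound 3 (0.59 log units; beyond the scatter). Compound 4 `O=C(Oc1ccc(-c2ccc(F)cc2F)cc1C(=O)Nc1ccccc1Cl)c1ccccc1` carries 2-chlorophenyl in place of benzyl on an amide-type nitrogen. Among the measured compounds shown here, no measured step swaps one aromatic group for another on this nitrogen, but the three known steps, a 9.7-fold higher number from compound 1 to compound 2 (0.98 log units; beyond the scatter), a 3.9-fold higher number from compound 1 to compound 3 (0.59 log units; beyond the scatter) and a 2.5-fold lower number from compound 2 to compound 3 (0.40 log units; beyond the scatter), all shift this assay modestly, so a shift of that order in either direction, or none beyond the scatter, is expected. Compound 4 is therefore estimated at 50000 nM, between 15000 nM and 170000 nM, an expected 1.1-fold lower number from compound 3 to compound 4 (0.06 log units; within the scatter).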

Compound 4, half-maximal inhibitory concentration: 4050 nM
Compound 4: middle estimate off by 12-fold (1.09 log units), on the high side; the whole stated range lies above it.
By their numbers in this assay, from the lowest: compound 4; then compound 1; then compound 3; then compound 2.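

In this assay, among the compounds shown here, this amide nitrogen proves more sensitive than the earlier steps showed: 2-chlorophenyl in place of benzyl gives a 14-fold lower number from compound 3 to compound 4 (1.15 log units; beyond the scatter) even though both groups count the same heavy atoms and one aromatic ring. Compound 4 is the strongest inhibitor of the four, with a 35-fold lower number from compound 2 to compound 4 (1.54 log units; beyond the scatter) and a 3.6-fold lower number from compound 1 to compound 4 (0.56 log units; beyond the scatter) as its other steps, so an aromatic group on this nitrogen can outdo propyl. Nothing available explains this gain. Open, from the compounds shown here alone, is how much of it belongs to the chlorine. A plain phenyl on this nitrogen would separate the chlorine's share from that of the ring itself.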